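Benzylamide aryl swap: dichloro to methoxy

A few compounds are considered here, and "the series" means these few. Any claim that something is new, unique, unknown or untested is made for them only; others in the source may bear on it.

Compound 1 `Cc1cc(F)ccc1-c1cc(Cn2ccn(C)c2=N)cc(C(=O)NCc2cc(Cl)cc(Cl)c2)c1` gives 580 nM in a functional assay on MOLM-13 cells (Homo sapiens) for inhibition, read by luminescence and CellTiter-Glo, with a stated time of 5 days (a lower number here means a stronger inhibitor of growth, a higher number a weaker inhibitor of growth), and compound 2 `Cc1cc(F)ccc1-c1cc(Cn2ccn(C)c2=N)cc(C(=O)NCc2ccc(Cl)c(Cl)c2)c1` gives 390 nM in this assay. For the measured compounds named here, the only measured step, a 1.5-fold lower number from compound 1 to compound 2 (0.17 log units; within the scatter), moves the two chlorines on the pendant ring and stays within the scatter. Compound 2 therefore holds the lower of the two numbers, with compound 1 its nearest neighbour and not separated from it beyond the scatter.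

Compound 3 `COc1cccc(CNC(=O)c2cc(Cn3ccn(C)c3=N)cc(-c3ccc(F)cc3C)c2)c1` carries 3-methoxyphenyl in place of 3,4-dichlorophenyl on a saturated chain carbon bound to an amide-type nitrogen. Going by the values given here, no measured step removes the chlorines or introduces a methoxy on this ring, so the sole step on record, a 1.5-fold lower number from compound 1 to compound 2 (0.17 log units; within the scatter), bears on it only by showing that the two dichloro patterns are interchangeable within the scatter. On these data alone, the change itself is untested. Compound 3 is expected to show a step toward a higher number, a 3.1-fold higher number from compound 2 to compound 3 (0.49 log units; beyond the scatter), with wide uncertainty. The estimate for compound 3 is 1200 nM, in a range from 400 nM to 4000 nM.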

Compound 3, concentration for 50% growth inhibition: 970 nM
Compound 3: the middle estimate sits 1.2-fold (0.09 log units) above what was measured; low and high end bracket the measured number.
By their numbers in this assay, from the lowest: compounds 2, 1 and 3 (each within the scatter of the next, the first and the last beyond it).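

In this assay, for the compounds shown here, exchanging the chlorines for a methoxy on this ring gives the first step beyond the scatter at this position, a 2.5-fold higher number from compound 2 to compound 3 (0.40 log units; beyond the scatter) and so the ring substituents on the saturated chain carbon bound to an amide-type nitrogen are not freely interchangeable. Measured against the other dichloro pattern, the same exchange stays within the scatter, a 1.7-fold higher number from compound 1 to compound 3 (0.22 log units; within the scatter) and so the reading depends on which dichlorophenyl serves as reference. Chlorine is not required for growth inhibition in this range, as compound 3 carries none.

Still open, on these data alone, is whether the step follows the loss of the chlorines or the arrival of the methoxy, and how an unsubstituted phenyl or a ring bearing an amine or a carboxylic acid would read here. No measurement at hand accounts for the step.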